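A few compounds are considered here, and "the series" means these few. Any claim that something is new, unique, unknown or untested is made for them only; others in the source may bear on it.

Measured in an ADME assay on microsomes from liver (Mus musculus) for metabolic stability, with a stated time of 10 min; a higher number here means that more of the compound is left, a lower number that less of the compound is left:
- compound 1 `O=C(O)C1CCN(C(=O)N2CC[C@](c3ccc(C(OCc4c(F)cccc4F)(C(F)(F)F)C(F)(F)F)cc3)(S(=O)(=O)c3ccc(F)cc3)C2)CC1`: 84%
- compound 2 `Cc1cccc(C)c1COC(c1ccc([C@]2(S(=O)(=O)c3ccc(F)cc3)CCN(C(=O)[C@H]3CC[C@H](C(=O)O)CC3)C2)cc1)(C(F)(F)F)C(F)(F)F`: 77%

Compound 2, with 77%, lies within the scatter of compound 1, with 84%, so these two values do not separate. Compound 3 `O=C(O)[C@H]1CC[C@H](C(=O)N2CC[C@](c3ccc(C(OCc4c(F)cccc4Cl)(C(F)(F)F)C(F)(F)F)cc3)(S(=O)(=O)c3ccc(F)cc3)C2)CC1` differs from compound 2 in one place: 2-chloro-6-fluorophenyl in place of 2,6-dimethylphenyl on a saturated chain carbon bound to an oxygen on a saturated carbon. Among the compounds with values here, no measured step exists for this change, so nothing beyond the scatter is expected in this assay. The expected step is a number 3 percentage points higher from compound 2 to compound 3 (within the scatter), a slight rise at most. For compound 3 the estimate is 80%, with an expected range of 65% to 92%.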

Compound 3, percent of the compound remaining: 87%
The estimate for compound 3 lay 7 percentage points below the measured number; measured number inside the range.
By their numbers in this assay, from the lowest: compounds 2, 1 and 3 (each within the scatter of the next).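

At the saturated chain carbon bound to an oxygen on a saturated carbon, replacing 2,6-dimethylphenyl with 2-chloro-6-fluorophenyl gives in this assay a step of a number 10 percentage points higher from compound 2 to compound 3 (within the scatter) and so does not separate the two compounds. In this read-out, the position accepts either substituted ring without a change beyond the scatter. No measurement bears on the cause of this result.

Still open, from the compounds shown here alone, is whether an unsubstituted phenyl ring or a basic amine at this position would hold the number in this assay within the same scatter.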